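This account rests on a few compounds, and the source may have more. Where it says the series, first, only, none or still open, it means among the compounds named here.

Compound 3 `NS(=O)(=O)NCC1CCN(c2cc(-c3cccc(Cl)c3)ncn2)CC1` gives 47500 nM in a functional assay on HT-29 cells (Homo sapiens) for antiproliferative activity, read by sulforhodamine B assay, with a stated time of 48 h (a lower number here means a stronger inhibitor of growth, a higher number a weaker inhibitor of growth), and stands as the higher of the two numbers shown. Its nearest neighbour is compound 1 `Cc1ccc(-c2cc(N3CCC(CNS(N)(=O)=O)CC3)ncn2)cc1`, which gives 33900 nM; the step of a 1.4-fold higher number from compound 1 to compound 3 (0.15 log units; within the scatter) stays within the scatter, so the two cannot be ordered. Compound 2 `COc1ccc(-c2cc(N3CCC(CNS(N)(=O)=O)CC3)ncn2)cc1` reaches only the assay limit at > 100000 nM. This is the case described by the limit of > 100000 nM in this assay, at which 1 of the 3 values shown sits. From that limit the step of an at least 2.1-fold lower number from compound 2 to compound 3 (0.32 log units; beyond the scatter) recovers some potency, while an at least 2.9-fold higher number from compound 1 to compound 2 (0.46 log units; beyond the scatter) shows the methoxy-bearing compound as the weaker of that pair.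

Compound 4 `COc1ccccc1-c1cc(N2CCC(CNS(N)(=O)=O)CC2)ncn1` carries 2-methoxyphenyl in place of 3-chlorophenyl on an aromatic carbon. Among the measured compounds shown here, two measured steps bear on it: an at least 2.9-fold higher number from compound 1 to compound 2 (0.46 log units; beyond the scatter), where a methoxy in place of a methyl pushed the number up to the limit, and an at least 2.1-fold lower number from compound 2 to compound 3 (0.32 log units; beyond the scatter), which reversed that loss. Since compound 4 brings back a methoxyphenyl, though as 2-methoxyphenyl rather than the group found in compound 2, a modest rise in the number is expected. Compound 4 is therefore estimated at 80000 nM, between 30000 nM and 200000 nM, with a fair chance that only a limit is returned. That estimate amounts to an expected step of a 1.7-fold higher number from compound 3 to compound 4 (0.23 log units; within the scatter).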

Compound 4, concentration for 50% growth inhibition: > 100000 nM
Compound 4 gave a limit, no number; the forecaster's own chance of this, stated with the estimate: 40%; middle value at least 1.2-fold (0.09 log units) from the limit.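

With 2-methoxyphenyl on this aromatic carbon, as with 4-methoxyphenyl, compound 4, like compound 2, returns only a limit in this assay: the limit of > 100000 nM in this assay, at which 2 of the 4 values shown sit. Against the two compounds that gave numbers, the new group falls behind, with an at least 2.1-fold higher number from compound 3 to compound 4 (0.32 log units; beyond the scatter) and an at least 2.9-fold higher number from compound 1 to compound 4 (0.46 log units; beyond the scatter), so among the compounds shown the loss with a methoxyphenyl is not confined to the 4-methoxyphenyl group. The step between the two methoxyphenyl compounds cannot be read, and they cannot be ordered.

From the compounds shown here alone, it remains open whether a hydroxyl or an amine on the phenyl ring at this position would also fall to the limit or would return a number. Also unresolved is whether any group here could give a much stronger inhibitor of growth than compound 1 and compound 3, whose numbers remain high.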